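The compounds below may be only part of what the source reports. "The series", "measured", "known", "first", "only" and "open" are said of these compounds alone.

Measured so far in a functional assay on HT-29 cells (Homo sapiens) for inhibition, read by sulforhodamine B assay, with a stated time of 48 h, tested at 10 uM; on this read-out lower numbers stand for less inhibition and higher numbers for more inhibition at the one concentration tested (going by the name of the read-out):

Compound 1 `Brc1cn2ccnc2c(-c2ccc3ncn(C4CCCCC4)c3c2)n1` gives 5.21%.
Compound 2 `O=Cc1ccc(-c2cn3ccnc3c(-c3ccc4ncn(C5CCCCC5)c4c3)n2)cc1` gives 17.5%.
Compound 3 `c1cn2cc(-c3ccsc3)nc(-c3ccc4ncn(C5CCCCC5)c4c3)c2n1` gives 5.68%.

Compound 3 stands second highest of the three numbers; its nearest neighbour is compound 1, a gap within the scatter, and its furthest is compound 2, a gap beyond the scatter. Among the measured steps, a number 0.5 percentage points higher from compound 1 to compound 3 (within the scatter), whereas a number 12.3 percentage points higher from compound 1 to compound 2 (beyond the scatter) and a number 11.8 percentage points lower from compound 2 to compound 3 (beyond the scatter).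

Compound 4 `Brc1ccc(-c2cn3ccnc3c(-c3ccc4ncn(C5CCCCC5)c4c3)n2)cc1` is not yet measured in this assay. Its change from compound 3 is 4-bromophenyl in place of thiophen-3-yl on an aromatic carbon, on an aromatic carbon of a six-membered aromatic ring with 2 nitrogen, part of a fused system of two rings.

For the measured compounds named here, the steps that bear on this are those around compound 2 and compound 3: a six-membered aromatic ring of carbon only at this place gave a modest rise over bromo and over thiophen-3-yl, but only one such ring, carrying a formyl group, has been tested. For compound 4 a modest rise is expected, a number 5.3 percentage points higher from compound 3 to compound 4 (within the scatter), with a fair chance it stays within the scatter. The estimate for compound 4 is 11%, range 0% to 24%.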

Compound 4, a percentage reported as inhibition, at one concentration (the size of the read-out at that concentration, not a potency): 20.9%
The estimate for compound 4 lay 9.9 percentage points below the measured number; low and high end bracket the measured number.
By their numbers in this assay, from the lowest: compounds 1 and 3 (each within the scatter of the next); then compounds 2 and 4 (each within the scatter of the next).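

In this assay, a second six-membered aromatic ring of carbon only at this position again stands clear of bromo, a number 15.7 percentage points higher from compound 1 to compound 4 (beyond the scatter), and of thiophen-3-yl, a number 15.2 percentage points higher from compound 3 to compound 4 (beyond the scatter). The rise therefore no longer rests on a single compound, and it does not depend on the formyl group, since exchanging formyl for bromo on that ring gives a number 3.4 percentage points higher from compound 2 to compound 4 (within the scatter). Nothing at hand explains why the 4-substituted phenyl rings read above thiophen-3-yl.

Still open, as far as these compounds go, is whether an unsubstituted phenyl ring at this position reads with compound 2 and compound 4 or with compound 1 and compound 3. Equally open, from the compounds shown here alone, is what an amine or a carboxylic acid in place of the bromo of 4-bromophenyl would do to the read-out.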